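From 3-methylphenyl to phenethyl on the shared core

The source may report more compounds than this note shows. Statements on the series, on what has been measured and on what is new or still open speak of the compounds shown alone.

Compound 1 `Cn1cc(/C=N/NC(N)=S)c2ccccc21` carries hydrogen on a saturated chain carbon bound to an aromatic nitrogen. In a toxicity assay on MRC5 cells (Homo sapiens) for cytotoxicity, read by MTT assay, with a stated time of 72 h (on this read-out higher numbers stand for an effect only at larger amounts of compound and lower numbers for an effect already at smaller amounts), compound 1 reaches only the limit of > 200000 nM, which is a limit of the assay and not a number (the limit of > 200000 nM in this assay, at which 1 of the 2 values shown sits). Going by the values given here, compound 2 `Cc1cccc(Cn2cc(/C=N/NC(N)=S)c3ccccc32)c1` places 3-methylphenyl at that carbon, and in this assay compound 2 gives 23000 nM, the only plain number among the values shown. That step is an at least 8.6-fold lower number from compound 1 to compound 2 (0.93 log units; beyond the scatter). Compound 3 `NC(=S)N/N=C/c1cn(CCCc2ccccc2)c2ccccc12` differs from compound 2 by phenethyl in place of 3-methylphenyl on a saturated chain carbon bound to an aromatic nitrogen. Among the compounds with values here, only that single measured step bears on this change, and it concerned putting an aromatic group where hydrogen had stood; compound 3 keeps such a group, so the move is expected to stay within the scatter, with no clear direction. Compound 3 is therefore estimated at 25000 nM, with a range from 8000 nM to 80000 nM. This estimate means a step of a 1.1-fold higher number from compound 2 to compound 3 (0.04 log units; within the scatter) is expected.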

Compound 3, half-maximal effective concentration: > 200000 nM
Compound 3: only a limit was reported; the forecaster's own chance of this, stated with the estimate: 15%; at least 8.0-fold (0.90 log units) between middle value and limit.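

At this position, an aromatic ring alone does not decide the outcome: 3-methylphenyl and phenethyl each bring one six-membered aromatic ring of carbon only, yet in this assay the change gives an at least 8.6-fold higher number from compound 2 to compound 3 (0.93 log units; beyond the scatter). Compound 3 gives only > 200000 nM, which is a limit of the assay and not a number. The step between compound 1 and compound 3 cannot be read, since both end at the same limit: the limit of > 200000 nM in this assay, at which 2 of the 3 values shown sit.

The change from 3-methylphenyl to phenethyl alters the methyl and the link to the ring together, and the compounds shown do not separate the two; plain phenyl at that carbon would help to tell them apart. From the compounds shown here alone, how an amine or a carboxylic acid on that ring would behave also remains open.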